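Sulfonamide variation on the chromene-pyridone series

The source may report more compounds than this note shows. Statements on the series, on what has been measured and on what is new or still open speak of the compounds shown alone.

Measured compounds:
compound 1 `CC1(C)C=C(n2ccccc2=O)c2cc(S(=O)(=O)Nc3ccccc3)ccc2O1` — 3.09 nM; 2 nM (2 entries)
compound 2 `CC1(C)C=C(n2ccccc2=O)c2cc(S(=O)(=O)N3CCOCC3)ccc2O1` — 85.1 nM

In a functional assay with Rattus norvegicus as the target (a higher number here means that more compound is needed for the effect, a lower number that less compound is needed), compound 1 gives 3.09 nM; 2 nM (2 entries), with the repeat entries agreeing (the several entries of compound 1 in this assay, 3.09 nM; 2 nM (2 entries)). In this assay, among the measured compounds shown here, compound 2 gives 85.1 nM, the only number available for it; a further entry for compound 2 carries no single value. Compound 3 `CN(c1ccccc1)S(=O)(=O)c1ccc2c(c1)C(n1ccccc1=O)=CC(C)(C)O2` is not yet measured in this assay. It differs from compound 2 in one place: methyl(phenyl)amino in place of morpholin-4-yl on a sulfonyl sulfur. The sulfonyl nitrogen thus stays fully substituted, as in compound 2, while the aromatic ring of carbon only on that nitrogen recalls compound 1. For the measured compounds named here, no step between measured compounds is available, so only the two values can be read side by side, and compound 1 stands at the lower number. The expected step from compound 2 to compound 3 is a decrease, a 4.3-fold lower number from compound 2 to compound 3 (0.63 log units; beyond the scatter), beyond the usual scatter. For compound 3 in this assay the estimate is 20 nM, within a range from 5 nM to 70 nM.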

Compound 3, half-maximal effective concentration: 1.74 nM
Compound 3: middle estimate off by 11-fold (1.06 log units), on the high side; measured number below the stated range.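

The step from morpholin-4-yl to methyl(phenyl)amino on a sulfonyl sulfur is a 49-fold lower number from compound 2 to compound 3 (1.69 log units; beyond the scatter) in this assay, so a fully substituted sulfonyl nitrogen does not by itself bring the higher number seen for compound 2. Compound 3 has no hydrogen on that nitrogen, yet its 1.74 nM reads close to compound 1 at 3.09 nM; 2 nM (2 entries), so the amide hydrogen of compound 1 is not needed for a low number in this pair. The repeat readings give the measure for that comparison: the several entries of compound 1 in this assay, 3.09 nM; 2 nM (2 entries)

The compounds shown do not separate the contribution of the morpholine oxygen from that of the aromatic ring of carbon only. Piperidin-1-yl and cyclohexyl(methyl)amino on the same sulfonyl sulfur would address that question.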